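Carboxylic acid in place of methyl ester on the pyridine

The source may report more compounds than this note shows. Statements on the series, on what has been measured and on what is new or still open speak of the compounds shown alone.

Compound 1 `O=C(O)c1ccc(-c2cnc(C(=O)CCc3ccc(-c4ccccc4)cc3)o2)cn1`: 44 nM
Compound 2 `COC(=O)c1ccc(-c2cnc(C(=O)CCc3ccc(-c4ccccc4)cc3)o2)nc1`: 2.2 nM
Compound 3 `COC(=O)c1cnc(C(=O)CCc2ccc(COc3ccccc3)cc2)o1`: 1.6 nM

In an assay for inhibition of Fatty-acid amide hydrolase 1 (Rattus norvegicus) (on this read-out lower numbers stand for stronger inhibition and higher numbers for weaker inhibition), compound 2 stands second highest of the three numbers; compound 3 gives a number within the scatter of it, while compound 1 gives a higher number beyond the scatter. The unmeasured compound 4 `O=C(O)c1cc(-c2cnc(C(=O)CCc3ccc(-c4ccccc4)cc3)o2)ccn1` differs from compound 2 in one place: 2-carboxypyridin-4-yl in place of 5-(methoxycarbonyl)pyridin-2-yl on an aromatic carbon. Within the data shown here, of the measured steps only one bears on this change, a 20-fold lower number from compound 1 to compound 2 (1.30 log units; beyond the scatter); there the acid-bearing pyridine of compound 1 gave way to the ester-bearing pyridine of compound 2 and the number fell sharply. Among the measured compounds shown here, in compound 4 the ester again gives way to a carboxylic acid, so a rise in this assay is expected, though the pyridine is also joined differently and no measured step separates the two parts of that earlier change, which leaves the size uncertain. Compound 4 is therefore expected to give 30 nM (range 8 nM to 120 nM), which would be an expected step of a 14-fold higher number from compound 2 to compound 4 (1.13 log units; beyond the scatter).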

Compound 4, inhibition constant: 50 nM
Compound 4: the middle estimate sits 1.7-fold (0.22 log units) below what was measured; the range from low to high includes it.
By their numbers in this assay, from the lowest: compounds 3 and 2 (each within the scatter of the next); then compounds 1 and 4 (each within the scatter of the next).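

In this assay, the second carboxylic acid behaves like the first: 2-carboxypyridin-4-yl in place of 6-carboxypyridin-3-yl gives a 1.1-fold higher number from compound 1 to compound 4 (0.06 log units; within the scatter), so these two acid-bearing pyridines, which differ in how the ring is joined and where the acid sits, cannot be told apart on this read-out. Among these compounds, replacing the ester-bearing pyridine with 2-carboxypyridin-4-yl gives a 23-fold higher number from compound 2 to compound 4 (1.36 log units; beyond the scatter), a large step that shows the 5-(methoxycarbonyl)pyridin-2-yl group of compound 2 standing apart from both acid-bearing groups, and not just from the one in compound 1. No measurement at hand explains this separation.

On these data alone, what remains open is how much of the large step belongs to the change from ester to carboxylic acid and how much to the way the pyridine is joined, as the ester and the acids here sit on differently joined rings. As far as these compounds go, it is also open where a primary amide, a nitrile or a hydroxymethyl group on the same pyridine would fall relative to the ester of compound 2 and the two acids.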